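Swapping the aryl ether of compound 3 for an anilino link

A few compounds are considered here, and "the series" means these few. Any claim that something is new, unique, unknown or untested is made for them only; others in the source may bear on it.

Measured compounds:
- compound 1 `Cc1ccc(Oc2ccc(C#N)cc2S(=O)(=O)NC(=O)NC(C)(C)C)cc1`: 750 nM
- compound 2 `CC(C)(C)NC(=O)NS(=O)(=O)c1cc(C#N)ccc1Oc1ccc(F)cc1`: 4350 nM
- compound 3 `CC(C)(C)NC(=O)NS(=O)(=O)c1cc(C#N)ccc1Oc1ccc(Cl)cc1`: 5640 nM

These three compounds share one core and differ only in the group on the outer aromatic ring. In a functional assay on HEK293 cells for antagonist activity at thromboxane A2 receptor (Homo sapiens), read by fluorescence and calcium flux (a lower number here means a stronger inhibitor, a higher number a weaker inhibitor), compound 1 gives 750 nM, and it gives the lowest number of the three. Compound 3 stands at the other end: it gives the highest number, with compound 2 nearest to it (a 1.3-fold higher number from compound 2 to compound 3 (0.11 log units; within the scatter)) and compound 1 furthest (a 7.5-fold higher number from compound 1 to compound 3 (0.88 log units; beyond the scatter)).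

Compound 4 `Cc1ccccc1Nc1ccc(C#N)cc1S(=O)(=O)NC(=O)NC(C)(C)C` has not yet been measured. Its change from compound 3 is (2-methylphenyl)amino in place of 4-chlorophenoxy on an aromatic carbon.

For the measured compounds named here, two measured steps bear on this change, though only in part. Going from methyl to fluoro (a 5.8-fold higher number from compound 1 to compound 2 (0.76 log units; beyond the scatter)) and from methyl to chloro (a 7.5-fold higher number from compound 1 to compound 3 (0.88 log units; beyond the scatter)) both raised the number by a modest amount, so a methyl group on the outer ring goes with a lower number than chloro. Nothing measured speaks to the amino link in place of the oxygen, or to the methyl sitting on a different carbon, so the expectation is uncertain. A lower number than compound 3 is expected, roughly in the direction of compound 1, with a wide range.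

Compound 4 is estimated to give 1500 nM in this assay, between 300 nM and 8000 nM. The expected step is a 3.8-fold lower number from compound 3 to compound 4 (0.58 log units; beyond the scatter).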

Compound 4, half-maximal inhibitory concentration: 2750 nM
For compound 4 the middle estimate is 1.8-fold (0.26 log units) below the measured one, and the stated range covers the measured number.
By their numbers in this assay, from the lowest: compound 1; then compounds 4, 2 and 3 (each within the scatter of the next, the first and the last beyond it).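

In this assay, for the compounds shown here, putting (2-methylphenyl)amino in place of 4-chlorophenoxy at this position gives a measurable gain (a 2.1-fold lower number from compound 3 to compound 4 (0.31 log units; beyond the scatter)), so activity here does not depend on the oxygen link that all the earlier compounds carry. Against the fluoro compound, the same kind of swap stays within the usual scatter (a 1.6-fold lower number from compound 2 to compound 4 (0.20 log units; within the scatter)), so the anilino compound cannot be ranked against that ether. The methyl ether keeps a clear lead (a 3.7-fold higher number from compound 1 to compound 4 (0.56 log units; beyond the scatter)), which shows that having a methyl on the outer ring is not enough on its own to reach the number of compound 1 once the link and the place of the methyl both differ.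

Because the link and the methyl position change together, the compounds shown cannot separate their contributions, and a sulfur or methylene link, or a methoxy group on the outer ring, remains open. No measurement is available that would explain any of these steps.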